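Two hits and a cyclobutyl ester to come

The compounds below may be only part of what the source reports. "The series", "measured", "known", "first", "only" and "open" are said of these compounds alone.

Compound 1 `CCCOC(=O)C1=C(C)NC(=O)NC1c1ccoc1` and compound 2 `CC1=C(C(=O)SC(C)C)C(c2ccoc2)NC(=O)N1` share one core. In an assay on membranes from HeLa cells for displacement of a labelled ligand from adenosine receptor A3 (Homo sapiens), read by scintillation counting, with a stated time of 180 min, tested at 1 uM (on this read-out lower numbers stand for less inhibition and higher numbers for more inhibition at the one concentration tested (going by the name of the read-out)), compound 1 gives 11%, and compound 2 gives 3%. Of the two numbers shown compound 2 holds the lower one, but the step of a number 8 percentage points lower from compound 1 to compound 2 (within the scatter) lies within the scatter; it came from isopropylsulfanyl in place of propoxy on a carbonyl carbon. Compound 3 `CC1=C(C(=O)OC2CCC2)C(c2ccoc2)NC(=O)N1` differs from compound 2 by cyclobutyloxy in place of isopropylsulfanyl on a carbonyl carbon. Among the measured compounds shown here, only that single measured step bears on this change, and since it stayed within the scatter, no shift beyond the scatter is expected in this assay for compound 3. Compound 3 is therefore estimated at 8%, between 0% and 20%, an expected step of a number 5 percentage points higher from compound 2 to compound 3 (within the scatter).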

Compound 3, a percentage reported as inhibition, at one concentration (the size of the read-out at that concentration, not a potency): 1%
For compound 3 the middle estimate is 7 percentage points above the measured one; low and high end bracket the measured number.
By their numbers in this assay, from the lowest: compounds 3, 2 and 1 (each within the scatter of the next).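

With cyclobutyloxy on the carbonyl carbon, a ring joins the open chains tested at this position in this assay: the exchange for isopropylsulfanyl gives a number 2 percentage points lower from compound 2 to compound 3 (within the scatter), and the exchange of propyl for cyclobutyl on the oxygen gives a number 10 percentage points lower from compound 1 to compound 3 (within the scatter). Neither replacement moves the number beyond the scatter, so the three compounds cannot be told apart here. Nothing available explains this result. As far as these compounds go, whether an amine, a carboxylic acid or a longer chain on this carbonyl carbon would shift the number beyond the scatter stays open. So does the effect of changes elsewhere on the shared core.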